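The compounds below may be only part of what the source reports. "The series", "measured", "known", "first", "only" and "open" are said of these compounds alone.

Compound 2 `O=C1C=CC(=O)c2ncncc21` is the shared core without any attached ring, and in a functional assay on BXPC-3 cells (Homo sapiens) for cytotoxicity, read by MTT assay, with a stated time of 72 h (on this read-out higher numbers stand for weaker inhibition and lower numbers for stronger inhibition), compound 2 gives 19400 nM. Compound 3 `COc1ccc(NC2=CC(=O)c3ncncc3C2=O)cc1OC` gives 1500 nM in this assay. Compound 1 `O=C1C(Nc2ccc(-c3ccccc3)cc2)=CC(=O)c2ncncc21` gives 500 nM in this assay and holds the lowest of the three numbers, beyond the scatter from compound 3 and much further from compound 2. Compound 4 `CCOC(=O)c1ccc(NC2=CC(=O)c3ncncc3C2=O)cc1` differs from compound 1 by ethoxycarbonyl in place of phenyl on an aromatic carbon. For the measured compounds named here, no such step between measured compounds exists, so the direction is uncertain; as compound 1 and compound 3 already differ beyond the scatter, a moderate shift toward a higher number is expected. Compound 4 is estimated at 1500 nM, within 500 nM to 5000 nM. The expected step is a 3.0-fold higher number from compound 1 to compound 4 (0.48 log units; beyond the scatter).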

Compound 4, half-maximal inhibitory concentration: 5900 nM
Beside the measured number, compound 4's estimate is 3.9-fold (0.59 log units) below it; measured number above the stated range.
By their numbers in this assay, from the lowest: compound 1; then compound 3; then compound 4; then compound 2.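

In this assay, for the compounds shown here, ethoxycarbonyl in place of phenyl on an aromatic carbon, para to a large group, gives a 12-fold higher number from compound 1 to compound 4 (1.07 log units; beyond the scatter) and is the first single-place change that can be read. It shows that this position is sensitive to its substituent, and that ethoxycarbonyl does not stand in for phenyl there. Nothing available explains the size of this step. As far as these compounds go, whether a pyridyl ring in the same place would stay near compound 1 remains open. So does where a carboxylic acid or an amide would fall.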